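The compounds below may be only part of what the source reports. "The series", "measured", "known", "first", "only" and "open" are said of these compounds alone.

In a functional assay on PANC-1 cells (Homo sapiens) for cytotoxicity, read by MTT assay, with a stated time of 72 h (on this read-out higher numbers stand for weaker inhibition and lower numbers for stronger inhibition), three compounds have been measured:

compound 1 `O=C1C(Nc2cccc(-c3ccccc3)c2)=CC(=O)c2ncncc21`: 2300 nM
compound 2 `CN1CCN(c2ccc(NC3=CC(=O)c4ncncc4C3=O)cc2)CC1`: 340 nM
compound 3 `O=C1C(Nc2ccc(C3CCCCC3)cc2)=CC(=O)c2ncncc21`: 900 nM

Among these, compound 2 gives the lowest number, and its gaps to both others lie beyond the usual scatter. Compound 4 `CCc1ccc(-c2ccc(NC3=CC(=O)c4ncncc4C3=O)cc2)cc1` has not yet been measured in this assay. It differs from compound 2 by 4-ethylphenyl in place of 4-methylpiperazin-1-yl on an aromatic carbon, with 4-ethylphenyl in place of 4-methylpiperazin-1-yl on an aromatic carbon.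

For the measured compounds named here, the one measured step that bears directly on this change is a 2.6-fold higher number from compound 2 to compound 3 (0.42 log units; beyond the scatter). It is modest, and it also removes 4-methylpiperazin-1-yl from an aromatic carbon, there in favour of cyclohexyl. Going by the values given here, there is no measured single-place step between compound 2 and compound 1, but compound 1 gives 2300 nM, which shows that a number well above that of compound 2 occurs within this small set. Among the compounds with values here, three compounds are a thin basis, and no measured step introduces 4-ethylphenyl itself. A rise similar to the cyclohexyl step or somewhat larger therefore seems the most reasonable expectation. The expected change is a 3.2-fold higher number from compound 2 to compound 4 (0.51 log units; beyond the scatter). For compound 4 the estimated value is 1100 nM, with an expected range from 400 nM to 3000 nM.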

Compound 4, half-maximal inhibitory concentration: 2300 nM
For compound 4 the middle estimate is 2.1-fold (0.32 log units) below the measured one, within the range that was stated.
By their numbers in this assay, from the lowest: compound 2; then compound 3; then compounds 1 and 4 (each within the scatter of the next).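

In this assay, 4-ethylphenyl at this position gives a 6.8-fold higher number from compound 2 to compound 4 (0.83 log units; beyond the scatter), so a second group made of carbon only also gives a higher number than 4-methylpiperazin-1-yl does. Among compounds 2, 3 and 4, which are the ones linked by single-place steps, both replacements of 4-methylpiperazin-1-yl go the same way, and neither of them goes against this pattern. The position also separates the two carbon-only groups, with a 2.6-fold higher number from compound 3 to compound 4 (0.41 log units; beyond the scatter), although that change swaps a non-aromatic ring for an aromatic one and adds an ethyl chain, so the step alone does not show which of the two matters.

Still open, from the compounds shown here alone, is where a morpholine ring, a dimethylamino group, a carboxylic acid or an unsubstituted phenyl ring would fall at this position, and whether the number depends on the ethyl chain at all. No measurement available here accounts for the differences among these compounds.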